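Aminooxy chain in place of hydrazide on an adenosine core

The source may report more compounds than this note shows. Statements on the series, on what has been measured and on what is new or still open speak of the compounds shown alone.

Compound 1 `Cc1nc2c(N)ncnc2n1[C@@H]1O[C@H](CN(C)CCC(N)=O)[C@@H](O)[C@H]1O` gives 400 nM in an assay on isolated protein for inhibition of S-adenosylmethionine decarboxylase proenzyme (Homo sapiens); on this read-out lower numbers stand for stronger inhibition and higher numbers for weaker inhibition. Compound 2 `CN(CCC(N)=O)C[C@H]1O[C@@H](n2cnc3c(N)ncnc32)[C@H](O)[C@@H]1O` gives 7000 nM. Compound 3 `CN(CCC(=O)NN)C[C@H]1O[C@@H](n2cnc3c(N)ncnc32)[C@H](O)[C@@H]1O` gives 1500 nM.

Compound 3 stands second highest of the three, a 4.7-fold lower number from compound 2 to compound 3 (0.67 log units; beyond the scatter), while compound 1 sits lower still. Compound 4 `CN(CCCCON)C[C@H]1O[C@@H](n2cnc3c(N)ncnc32)[C@H](O)[C@@H]1O` differs from compound 3 by 2-(aminooxy)ethyl in place of aminocarbamoyl on a saturated chain carbon, two bonds along the chain from an amine nitrogen. Among the measured compounds shown here, neither measured step touches this part of the chain: an 18-fold higher number from compound 1 to compound 2 (1.24 log units; beyond the scatter) concerns the aromatic methyl, and a 4.7-fold lower number from compound 2 to compound 3 (0.67 log units; beyond the scatter) the amide nitrogen, so no step here bears directly on the change. Compound 4 is therefore expected to stay near compound 3, with a 1.3-fold lower number from compound 3 to compound 4 (0.10 log units; within the scatter) judged no larger than the scatter. Compound 4 is estimated at 1200 nM, between 250 nM and 6000 nM.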

Compound 4, half-maximal inhibitory concentration: 18 nM
Compound 4: middle estimate off by 67-fold (1.82 log units), on the high side, outside the stated range (below it).
By their numbers in this assay, from the lowest: compound 4; then compound 1; then compound 3; then compound 2.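

Among the compounds shown here, at this position the chain end matters far more than the earlier compounds showed: 2-(aminooxy)ethyl in place of aminocarbamoyl gives an 83-fold lower number from compound 3 to compound 4 (1.92 log units; beyond the scatter), and in place of carbamoyl it gives a 390-fold lower number from compound 2 to compound 4 (2.59 log units; beyond the scatter). Leaving and entering groups both count 4 heavy atoms, so in this assay this large shift comes with no change in that count. Nothing measured here accounts for the shift.

From the compounds shown here alone, it remains open whether the aminooxy end or the chain itself carries the shift, which a simple amine at the chain end or a longer chain would test. Going by these compounds, it is also open whether the aromatic methyl of compound 1 would lower the number further on this chain.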